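The source may report more compounds than this note shows. Statements on the series, on what has been measured and on what is new or still open speak of the compounds shown alone.

Values in a functional assay on QGY-7703 cells (Homo sapiens) for cytotoxicity, read by MTT assay, with a stated time of 24 h; on this read-out higher numbers stand for weaker inhibition and lower numbers for stronger inhibition:
- compound 1 `O=C1/C(=C/c2ccccc2F)CN(S(=O)(=O)c2ccc(F)cc2)C/C1=C\c1ccccc1F` gives 8500 nM
- compound 2 `COc1cc(/C=C2\CN(S(=O)(=O)c3ccc(F)cc3)C/C(=C\c3cc(OC)c(OC)c(OC)c3)C2=O)cc(OC)c1OC` gives 2220 nM
- compound 3 `N#Cc1ccc(/C=C2\CN(S(=O)(=O)c3ccc(F)cc3)C/C(=C\c3ccccc3F)C2=O)cc1` gives 20100 nM
- compound 4 `COc1cc(/C=C2\CN(S(=O)(=O)c3ccc(F)cc3)C/C(=C\c3ccccc3F)C2=O)cc(OC)c1OC` is not yet measured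

Compound 3 has the highest number of the three. The change to compound 4 is 3,4,5-trimethoxyphenyl in place of 4-cyanophenyl on a double-bonded chain carbon bound to a double-bonded ring carbon. Going by the values given here, the only measured single-place step is a 2.4-fold higher number from compound 1 to compound 3 (0.37 log units; beyond the scatter), modest but beyond the scatter. Reversing that kind of move suggests a lower number. Compound 2 carries 3,4,5-trimethoxyphenyl where compound 1 carries 2-fluorophenyl, and its number is the lower of the two. A larger step toward a lower number is therefore expected, estimated as a 4.5-fold lower number from compound 3 to compound 4 (0.65 log units; beyond the scatter). The estimate for compound 4 is 4500 nM, with an expected range of 1800 nM to 11000 nM.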

Compound 4, half-maximal inhibitory concentration: 13300 nM
Beside the measured number, compound 4's estimate is 3.0-fold (0.47 log units) below it; measured number outside the range, above it.
By their numbers in this assay, from the lowest: compound 2; then compounds 1, 4 and 3 (each within the scatter of the next, the first and the last beyond it).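

In this assay, with 2-fluorophenyl kept on the other double-bonded chain carbon, 3,4,5-trimethoxyphenyl gives no separation from 4-cyanophenyl (a 1.5-fold lower number from compound 3 to compound 4 (0.18 log units; within the scatter)) or from 2-fluorophenyl (a 1.6-fold higher number from compound 1 to compound 4 (0.19 log units; within the scatter)). The lower number of compound 2 appears only with 3,4,5-trimethoxyphenyl on both chain carbons (a 6.0-fold higher number from compound 2 to compound 4 (0.78 log units; beyond the scatter)), so the effect of this change depends on the group at the other place. No available evidence accounts for this dependence.

Open, as far as these compounds go, is whether an amine or a carboxylic acid at this place would move the number beyond the scatter with 2-fluorophenyl retained.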